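This account rests on a few compounds, and the source may have more. Where it says the series, first, only, none or still open, it means among the compounds named here.

In an assay on MCF7 cells for inhibition of Steryl-sulfatase (Homo sapiens), read by scintillation counting, with a stated time of 5 h, tested at 0.1 uM (on this read-out lower numbers stand for a weaker effect and higher numbers for a stronger effect at the one concentration tested), the number tells how strongly a compound blocks the enzyme at one fixed concentration. Compound 1 `C[Si](C)(c1ccc(OS(N)(=O)=O)cc1)c1ccc(OS(N)(=O)=O)cc1` carries a sulfamoyl on an oxygen on each of its two aromatic rings, and in this assay compound 1 gives 35.8%. Compound 2 `C[Si](C)(c1ccc(O)cc1)c1ccc(OS(N)(=O)=O)cc1` keeps only one sulfamoyl; in this assay compound 2 gives 25.2%, the lowest of the two plain numbers shown, with compound 1 as its nearest neighbour. Compound 3 `NS(=O)(=O)Oc1ccc(Cc2ccc(OS(N)(=O)=O)cc2)cc1` has a different core; in this assay compound 3 gives < 10%, which is a limit of the assay rather than a number, as described in the limit of < 10% in this assay, at which 1 of the 3 values shown sits.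

Compound 4 `C[Si](C)(c1ccc(O)cc1)c1ccc(O)cc1` is not yet measured. It differs from compound 2 in one place: hydrogen in place of sulfamoyl on an oxygen on an aromatic ring. For the measured compounds named here, the one measured step that bears on this change is a number 10.6 percentage points lower from compound 1 to compound 2 (beyond the scatter), where the same change, hydrogen in place of sulfamoyl on an oxygen on an aromatic ring, cost a modest but real amount. Taking away the last sulfamoyl is expected to cost at least as much again, so a number 17.2 percentage points lower from compound 2 to compound 4 (beyond the scatter) is the expected step, downward in this assay. Compound 4 is therefore estimated at 8%, within a range from 0% to 18%, and most likely reported only as a limit.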

Compound 4, a percentage reported as inhibition, at one concentration (the size of the read-out at that concentration, not a potency): < 10%
Compound 4 ended at the assay's limit; the forecaster's own chance of this, stated with the estimate: 60%; the middle value is on the limit's open side.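

In this assay compound 4 gives < 10%, which is a limit of the assay and not a number. For the compounds shown here, with the last sulfamoyl replaced by hydrogen, the result is a number at least 15.2 percentage points lower from compound 2 to compound 4 (beyond the scatter), so the single sulfamoyl of compound 2 is not a spare group: the change from sulfamoyloxy to hydroxy lowers the read-out here as well as in the earlier step, a number 10.6 percentage points lower from compound 1 to compound 2 (beyond the scatter), and the earlier compounds could show this only for the loss of one sulfamoyl out of two. Compound 4 has no sulfamoyl left and now sits at the bottom of what this read-out can report: the limit of < 10% in this assay, at which 2 of the 4 values shown sit.

From the compounds shown here alone, the true size of the step from compound 2 to compound 4 stays open, since only its smallest possible size can be read from a limit. Also open, going by these compounds, is whether something else on that oxygen, such as a methyl group or an acetyl group, or an amine put in place of the sulfamoyloxy, would keep any of the effect that the sulfamoyl gives on this core.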